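Turning an amide into a urea on the shared core

This account rests on a few compounds, and the source may have more. Where it says the series, first, only, none or still open, it means among the compounds named here.

In a functional assay on MOLT-4 cells (Homo sapiens) for inhibition, read by sulforhodamine B assay, with a stated time of 48 h (on this read-out higher numbers stand for weaker inhibition of growth and lower numbers for stronger inhibition of growth), compound 1 `COc1cc(-c2nn(-c3cccc(NC(=O)Nc4cc(C(F)(F)F)cc(C(F)(F)F)c4)c3)cc2-c2ccncc2)ccc1Cl` gives 4480 nM. In the same assay compound 3 `O=C(Nc1cccc(-n2cc(-c3ccncc3)c(-c3ccc(Cl)c(O)c3)n2)c1)Nc1cc(C(F)(F)F)cc(C(F)(F)F)c1` gives 4360 nM. For compound 2 `COc1cc(-c2nn(-c3cccc(NC(=O)c4cccc(C(F)(F)F)c4)c3)cc2-c2ccncc2)ccc1Cl` this assay gives only a limit, > 50000 nM, and not a number.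

Going by the values given here, compound 2 therefore stands apart from the other two: its growth inhibition was too weak to yield a value, and it is the one compound sitting at the limit of > 50000 nM in this assay, at which 1 of the 3 values shown sits. Compounds 1 and 3 are both ureas and lie close together; the step of a 1.0-fold lower number from compound 1 to compound 3 (0.01 log units; within the scatter) confirms that swapping hydrogen for methyl on the aromatic oxygen changes nothing measurable.

Compound 4 `COc1cc(-c2nn(-c3cccc(NC(=O)Nc4ccc(Cl)c(C(F)(F)F)c4)c3)cc2-c2ccncc2)ccc1Cl` is not yet measured. It differs from compound 2 in one place: (4-chloro-3-(trifluoromethyl)phenyl)amino in place of 3-(trifluoromethyl)phenyl on a carbonyl carbon. This rebuilds the amide of compound 2 into a urea of the same type as compounds 1 and 3, with a chlorine added on the aryl ring. Among the compounds with values here, no measured step covers exactly this change, so the expectation rests on the two ureas, which sit near one another and far from the limit of compound 2.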

Compound 4, concentration for total growth inhibition: 7960 nM
Compound 4: middle estimate off by 1.6-fold (0.20 log units), on the low side; the measured number falls inside the stated range.
By their numbers in this assay, from the lowest: compounds 3, 1 and 4 (each within the scatter of the next). At a limit, above all of these: compound 2.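

In this assay the change on the carbonyl carbon gives an at least 6.2-fold lower number from compound 2 to compound 4 (0.79 log units; beyond the scatter) and turns an amide without a readable value into a urea with one, the first comparison shown across this change. Compound 4 also stays within the scatter of compound 1, so a urea with a single trifluoromethyl and a chlorine on its aryl ring fits alongside the bis(trifluoromethyl) ureas. The full size of the step remains unknown, as the value for compound 2 is a limit and not a number: the limit of > 50000 nM in this assay, at which 1 of the 4 values shown sits.

The step brings in the nitrogen with its hydrogen and the chlorine together, so their shares cannot be separated; a urea carrying 3-(trifluoromethyl)phenyl without the chlorine would pull them apart. Also open, as far as these compounds go, is how a thiourea, with sulfur in place of the carbonyl oxygen, would compare.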